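Sulfonyl-linked hydroxyamides: replacing the fluorinated ring with pyridine

The source may hold more compounds than are shown below. What is called first, only, known or untested is meant among the compounds shown, and "the series" means these compounds.

Of the compounds shown here, two have numbers so far. Compound 1 `CC(O)(C(=O)Nc1ccc(S(=O)(=O)c2ccccc2F)cc1)C(F)(F)F` gives 1300 nM in a functional assay (Cavia porcellus) with sulfonylurea receptors; K-ATP channels (Homo sapiens) as the target; on this read-out higher numbers stand for weaker inhibition and lower numbers for stronger inhibition. Compound 2 `CC(O)(C(=O)Nc1ccc(C(=O)c2ccc(F)cc2)cc1)C(F)(F)F` gives 14000 nM in this assay, the higher of the two numbers; the gap between compound 1 and compound 2 lies beyond the scatter, so compound 1 stands as the lower of the two numbers and compound 2 as the higher. For the measured compounds named here, no step between measured compounds that differ in a single place is available, so nothing is known yet about how a change confined to the ring on the sulfonyl sulfur moves the read-out.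

The next compound, compound 3 `CC(O)(C(=O)Nc1ccc(S(=O)(=O)c2ccccn2)cc1)C(F)(F)F`, keeps the core of compound 1 and differs from it only there: pyridin-2-yl in place of 2-fluorophenyl on a sulfonyl sulfur. Going by the values given here, with no measured step to lean on, the expected step from compound 1 to compound 3 is a 1.4-fold higher number from compound 1 to compound 3 (0.14 log units; within the scatter), judged to stay within the scatter rather than in a definite direction. Compound 3 is therefore estimated at 1800 nM in this assay, with a range from 600 nM to 5500 nM.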

Compound 3, half-maximal inhibitory concentration: 600 nM
Beside the measured number, compound 3's estimate is 3.0-fold (0.48 log units) above it, and the stated range covers the measured number.
By their numbers in this assay, from the lowest: compound 3; then compound 1; then compound 2.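

For the compounds shown here, the exchange of 2-fluorophenyl for pyridin-2-yl on a sulfonyl sulfur gives the first single-place step, read in this assay (a 2.2-fold lower number from compound 1 to compound 3 (0.34 log units; beyond the scatter)), and it shows that a change confined to this ring can move the read-out beyond the scatter, here towards stronger inhibition. The ring therefore accepts a nitrogen-containing aromatic group without loss on this read-out, but the exchange removes the fluorine and brings in the ring nitrogen together, with one hydrogen-bond acceptor entering and none leaving, and this single step cannot separate those two parts of the change. No measurement here bears on why the number falls.

Still open, going by these compounds, is how a plain phenyl ring or a pyridin-3-yl ring on the sulfonyl sulfur would read, which would show whether the fluorine or the nitrogen carries the step, and whether an amine or a carboxylic acid on the pyridine ring would be accepted. Also open, on these data alone, is whether the same exchange gives a step of like size and direction in the carbonyl-linked compound 2.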